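Inverting two ring stereocentres of compound 1

The compounds below may be only part of what the source reports. "The series", "measured", "known", "first", "only" and "open" are said of these compounds alone.

In a functional assay on a cell-free system (plasma, Homo sapiens), with a stated time of 3 min (on this read-out lower numbers stand for stronger inhibition and higher numbers for weaker inhibition), compound 1 `O=C(NCc1cc(Cl)ccc1-n1cnnn1)[C@@H]1[C@H]2C[C@H]2CN1C(=O)[C@H](O)c1ccccc1` gives 960 nM, compound 2 `CC(C)(C)C[C@@H](O)C(=O)N1C[C@@H]2C[C@@H]2[C@H]1C(=O)NCc1cc(Cl)ccc1-n1cnnn1` gives 910 nM and compound 3 `O=C(NCc1cc(Cl)ccc1-n1cnnn1)[C@@H]1[C@H]2C[C@H]2CN1C(=O)[C@H](O)Cc1ccccc1` gives 1200 nM. The steps among these three all stay within the scatter: a 1.1-fold lower number from compound 1 to compound 2 (0.02 log units; within the scatter), a 1.3-fold higher number from compound 1 to compound 3 (0.10 log units; within the scatter) and a 1.3-fold higher number from compound 2 to compound 3 (0.12 log units; within the scatter). Compound 1 therefore holds no distinct place in this small set.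

Compound 4 `O=C(NCc1cc(Cl)ccc1-n1cnnn1)[C@@H]1[C@@H]2C[C@@H]2CN1C(=O)[C@H](O)c1ccccc1` changes only the core of compound 1: the two compounds have the same atoms and bonds and differ only in configuration as drawn: 2 of 4 stereo elements differ; a stereocentre at a saturated ring carbon is drawn S in compound 1 and R in compound 4; a stereocentre at a saturated ring carbon is drawn R in compound 1 and S in compound 4. All three measured steps alter the side chain on the carbon bearing the oxygen, and none touches these ring stereocentres. Within the data shown here, they show a flat response to side-chain changes but give no direct size for this inversion, and the series contains no other stereochemical pair. Compound 1 at 960 nM is the only anchor, so the estimate is loose. A moderate move toward a higher number is expected, with the estimated step being a 1.9-fold higher number from compound 1 to compound 4 (0.27 log units; within the scatter). For compound 4 the expected value is 1800 nM, with an estimated range from 450 nM to 8000 nM.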

Compound 4, half-maximal inhibitory concentration: 700 nM
Estimate against measurement, compound 4: 2.6-fold (0.41 log units) above, within the range that was stated.
By their numbers in this assay, from the lowest: compounds 4, 2, 1 and 3 (each within the scatter of the next).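

In this assay, inverting the two ring stereocentres gives a 1.4-fold lower number from compound 1 to compound 4 (0.14 log units; within the scatter). Among these compounds, this is the first direct reading on the configuration of the core, as the earlier steps only altered the side chain, and here the change does not separate from the scatter. The reading can be assigned to configuration alone, since nothing else varies in this pair: the fact that compounds 1 and 4 differ only in the configuration as drawn.

On these data alone, the inversion is read only with the phenyl group of compound 1, so it remains open whether it behaves alike with the neopentyl of compound 2 or the benzyl of compound 3, and whether inverting one ring stereocentre alone matches inverting both. Also open, as far as these compounds go, is how either core configuration responds to a carboxylic acid or an amine in place of the phenyl.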